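Cytotoxicity of Two Quinolinone Amines and an Untested Analogue

This account rests on a few compounds, and the source may have more. Where it says the series, first, only, none or still open, it means among the compounds named here.

Compound 1 `CCc1ccc2[nH]c(=O)c(CN(Cc3ccc(C(C)(C)C)cc3)Cc3ccc(F)c(F)c3)cc2c1`: > 33000 nM
Compound 2 `Cc1ccc2[nH]c(=O)c(CN(Cc3ccc(OCCO)cc3)Cc3ccc(C(C)(C)C)cc3)cc2c1`: > 5000 nM

In a toxicity assay on MDCK cells (Canis lupus familiaris) for cytotoxicity, read by crystal violet staining, with a stated time of 48 h (on this read-out higher numbers stand for lower toxicity in this test and lower numbers for higher toxicity in this test), compound 1 reaches only a limit, > 33000 nM, with no number beneath it (the limit of > 33000 nM in this assay, at which 1 of the 2 values shown sits). Compound 2 likewise gives only a limit in this assay, > 5000 nM (the limit of > 5000 nM in this assay, at which 1 of the 2 values shown sits). Both values shown are therefore limits, and no ordering between compound 1 and compound 2 can be read from them. Compound 3 `Cc1ccc2[nH]c(=O)c(CN(Cc3ccc(C(C)(C)C)cc3)C(C)c3ccc(N(C)C)c(Cl)c3)cc2c1` has not yet been measured; it differs from compound 2 by 1-(3-chloro-4-(dimethylamino)phenyl)ethyl in place of 4-(2-hydroxyethoxy)benzyl on an amine nitrogen. Going by the values given here, no measured step frames this change, so its effect in this assay is open. Compound 3 is expected to land around 15000 nM, between 4000 nM and 50000 nM, which corresponds to an estimated step that the limit leaves unreadable from compound 2 to compound 3.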

Compound 3, half-maximal cytotoxic concentration: 9800 nM
The estimate for compound 3 lay 1.5-fold (0.18 log units) above the measured number; low and high end bracket the measured number.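

Going by these compounds alone, no step from compound 2 to compound 3 can be read in this assay: compound 2 gives only a limit, > 5000 nM. The compounds shown leave open what 1-(3-chloro-4-(dimethylamino)phenyl)ethyl in place of 4-(2-hydroxyethoxy)benzyl changes in this read-out.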